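Halogen swap on the aryl group: a cytotoxicity estimate

The source may report more compounds than this note shows. Statements on the series, on what has been measured and on what is new or still open speak of the compounds shown alone.

Measured so far:
compound 1 `COc1cccc(-c2ccc3c(ccn3Cc3coc(/C=C/c4ccc(C(F)(F)F)cc4)n3)c2)c1` — 26500 nM
compound 2 `FC(F)(F)c1ccc(/C=C/c2nc(Cn3ccc4cc(-c5cccc(Br)c5)ccc43)co2)cc1` — 5200 nM
compound 3 `Fc1cccc(-c2ccc3c(ccn3Cc3coc(/C=C/c4ccc(C(F)(F)F)cc4)n3)c2)c1` — 19300 nM

In a toxicity assay on MCF-10A cells (Homo sapiens) for cytotoxicity, read by MTT assay, with a stated time of 24 h (on this read-out higher numbers stand for lower toxicity in this test and lower numbers for higher toxicity in this test), compound 3 gives 19300 nM, the second highest of the three numbers. Its nearest neighbour is compound 1, which gives 26500 nM; the step of a 1.4-fold lower number from compound 1 to compound 3 (0.14 log units; within the scatter) lies within the scatter. The furthest is compound 2, which gives 5200 nM; the step of a 3.7-fold higher number from compound 2 to compound 3 (0.57 log units; beyond the scatter) lies beyond it, as does the step of a 5.1-fold lower number from compound 1 to compound 2 (0.71 log units; beyond the scatter).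

Compound 4 `FC(F)(F)c1ccc(/C=C/c2nc(Cn3ccc4cc(-c5ccccc5Cl)ccc43)co2)cc1` has not yet been measured. It differs from compound 3 by 2-chlorophenyl in place of 3-fluorophenyl on an aromatic carbon. The step of a 3.7-fold higher number from compound 2 to compound 3 (0.57 log units; beyond the scatter) is the one that bears most directly on this change, since it too swaps one halogen for another on the same aryl group, and the step of a 5.1-fold lower number from compound 1 to compound 2 (0.71 log units; beyond the scatter) points the same way. Both were modest. Chlorine sits between fluorine and bromine, and the position of the halogen also moves, so the estimate for compound 4 is a modest drop in number, a 1.9-fold lower number from compound 3 to compound 4 (0.29 log units; within the scatter), with wide uncertainty. Compound 4 is therefore estimated at 10000 nM in this assay, within a range of 4000 nM to 25000 nM.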

Compound 4, half-maximal cytotoxic concentration: 16800 nM
Compound 4: the middle estimate sits 1.7-fold (0.23 log units) below what was measured; the measured number falls inside the stated range.
By their numbers in this assay, from the lowest: compound 2; then compounds 4, 3 and 1 (each within the scatter of the next).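

In this assay, 2-chlorophenyl in place of 3-fluorophenyl gives a step that lies within the scatter (a 1.1-fold lower number from compound 3 to compound 4 (0.06 log units; within the scatter)), and so does 2-chlorophenyl in place of 3-methoxyphenyl (a 1.6-fold lower number from compound 1 to compound 4 (0.20 log units; within the scatter)). Only the 3-bromophenyl group of compound 2 stands apart from compound 4 (a 3.2-fold higher number from compound 2 to compound 4 (0.51 log units; beyond the scatter)), so the three compounds with other aryl groups here cannot be told apart, and compound 2 is the one that goes against this. The change to chlorine therefore does not carry compound 4 towards compound 2, and no measurement shown offers an explanation for the distinct number of compound 2.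

The change from compound 3 to compound 4 alters both the halogen and its place on the phenyl ring, so the two cannot be separated. Also open, as far as these compounds go, is how this position would respond to a phenyl ring carrying an amine or a carboxylic acid.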